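The source may report more compounds than this note shows. Statements on the series, on what has been measured and on what is new or still open speak of the compounds shown alone.

Measured in a functional assay on HepG2 cells (Homo sapiens) for antiproliferative activity, read by MTT assay, with a stated time of 48 h; a higher number here means a weaker inhibitor, a lower number a stronger inhibitor
Compound 1 `O=C(/C=C/c1cn(S(=O)(=O)c2cccc([N+](=O)[O-])c2)c2ccccc12)c1ccncc1` gives 42600 nM
Compound 2 `COc1ccc(S(=O)(=O)n2cc(/C=C/C(=O)c3ccncc3)c3ccccc32)cc1` gives 26000 nM

Compound 2 cannot be ranked against compound 1, since their two values lie within the scatter of each other. Compound 3 `O=C(/C=C/c1cn(S(=O)(=O)c2ccc(Cl)cc2)c2ccccc12)c1ccncc1` has not yet been measured in this assay. It carries chloro in place of methoxy on an aromatic carbon, para to a large group, which turns 4-methoxyphenyl to 4-chlorophenyl (chloro in place of methoxy on an aromatic carbon). For the measured compounds named here, only one measured step bears on this change, and it also alters the aromatic group on the sulfonyl sulfur. Going by the values given here, because a 1.6-fold lower number from compound 1 to compound 2 (0.21 log units; within the scatter) stayed within the scatter, no step beyond the scatter is expected in either direction, though no measured compound yet carries chloro. The expected change is a 1.1-fold higher number from compound 2 to compound 3 (0.03 log units; within the scatter). Compound 3 is estimated at 28000 nM, with an expected range of 11000 nM to 65000 nM.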

Compound 3, half-maximal inhibitory concentration: 35100 nM
Beside the measured number, compound 3's estimate is 1.3-fold (0.10 log units) below it, and the stated range covers the measured number.
By their numbers in this assay, from the lowest: compounds 2, 3 and 1 (each within the scatter of the next).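

With chloro in place of methoxy, this assay shows a 1.4-fold higher number from compound 2 to compound 3 (0.13 log units; within the scatter) and, with 4-chlorophenyl in place of 3-nitrophenyl, a 1.2-fold lower number from compound 1 to compound 3 (0.08 log units; within the scatter) on the same sulfonyl sulfur. Chloro, which neither compound 1 nor compound 2 carries, therefore gives a third aromatic group at this place, and compound 1, compound 2 and compound 3 still cannot be ranked against one another. Nothing available accounts for this lack of separation.

From the compounds shown here alone, whether an amine or a carboxylic acid at the same aromatic carbon, or a longer chain in place of the whole aromatic group on the sulfur, would give a step beyond the scatter remains open. Every step shown lies on that aromatic group, so the effect of changes elsewhere on the shared core also remains open.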